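Swapping an ester for an aryl ketone on a penam scaffold

This account rests on a few compounds, and the source may have more. Where it says the series, first, only, none or still open, it means among the compounds named here.

Three compounds have been tested in a functional assay on OE19 cells (Homo sapiens) for cytotoxicity, read by MTT assay, with a stated time of 48 h; a higher number here means a weaker inhibitor, a lower number a stronger inhibitor:
compound 1 `CCOC(=O)/C=C1/C(=O)N2[C@@H]1SC(C)(C)[C@@H]2C(=O)OC(c1ccccc1)c1ccccc1` gives 11200 nM;
compound 2 `CC(=O)/C=C1/C(=O)N2[C@@H]1SC(C)(C)[C@@H]2C(=O)OC(c1ccccc1)c1ccccc1` gives 51900 nM;
compound 3 `CC1(C)S[C@@H]2/C(=C\C(=O)OCc3ccccc3)C(=O)N2[C@H]1C(=O)OC(c1ccccc1)c1ccccc1` gives 8200 nM.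

Compound 3 has the lowest number of the three, though its gap to compound 1 is within the scatter a 1.4-fold lower number from compound 1 to compound 3 (0.14 log units; within the scatter); only compound 2 stands clearly apart a 6.3-fold lower number from compound 2 to compound 3 (0.80 log units; beyond the scatter).

Compound 4 `CC1(C)S[C@@H]2/C(=C\C(=O)c3cc(F)cc(F)c3)C(=O)N2[C@H]1C(=O)OC(c1ccccc1)c1ccccc1` differs from compound 3 in one place: 3,5-difluorophenyl in place of benzyloxy on a carbonyl carbon. Within the data shown here, the one step that bears on this, replacing an ester substituent on the same carbonyl carbon with a plain ketone substituent, gave a 4.6-fold higher number from compound 1 to compound 2 (0.67 log units; beyond the scatter). Compound 4 keeps an aromatic ring but loses the ester oxygen, so a modest weakening is expected, a 1.7-fold higher number from compound 3 to compound 4 (0.23 log units; within the scatter), and compound 4 is estimated at 14000 nM, within 4500 nM to 45000 nM.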

Compound 4, half-maximal inhibitory concentration: 17600 nM
Beside the measured number, compound 4's estimate is 1.3-fold (0.10 log units) below it; the measured number falls inside the stated range.
By their numbers in this assay, from the lowest: compounds 3, 1 and 4 (each within the scatter of the next, the first and the last beyond it); then compound 2.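

On this carbonyl carbon, the ketone bearing 3,5-difluorophenyl stands apart from the benzyloxy ester, with a 2.1-fold higher number from compound 3 to compound 4 (0.33 log units; beyond the scatter) as the step, but it cannot be told apart from the ethoxy ester, with a 1.6-fold higher number from compound 1 to compound 4 (0.20 log units; within the scatter) as the step. Against the methyl ketone, the aromatic ring gives a 2.9-fold lower number from compound 2 to compound 4 (0.47 log units; beyond the scatter) as the step, so a ketone here need not sit as high as compound 2. No evidence here explains these differences.

On these data alone, whether the two fluorines matter remains open without a plain phenyl ketone for comparison. Also open, as far as these compounds go, is how an amine on that ring would change the number.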